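Aryl variation on the saturated ring carbon: compound 4

This account rests on a few compounds, and the source may have more. Where it says the series, first, only, none or still open, it means among the compounds named here.

Three compounds share one core and differ only in the group on a saturated ring carbon. Compound 1 `COc1cc(N2C(N)=C(C#N)C(c3c(OC)ccc4ccccc34)C3=C2CC(C)(C)CC3=O)cc(OC)c1OC` carries 2-methoxynaphthalen-1-yl there, and in a functional assay on Ehrlich cells (Mus musculus) for cytotoxicity, tested at 10 ug/mL (a higher number here means a stronger effect of the compound at the concentration tested, a lower number a weaker effect), compound 1 gives 0%. Compound 2 `COc1cc(N2C(N)=C(C#N)C(c3ccccc3Cl)C3=C2CC(C)(C)CC3=O)cc(OC)c1OC` carries 2-chlorophenyl, and in this assay compound 2 gives 10%. Compound 3 `COc1cc(N2C(N)=C(C#N)C(c3ccc(C)o3)C3=C2CC(C)(C)CC3=O)cc(OC)c1OC` carries 5-methylfuran-2-yl, and in this assay compound 3 gives 21%, the highest of the three numbers. The measured steps are a number 10 percentage points higher from compound 1 to compound 2 (within the scatter), a number 21 percentage points higher from compound 1 to compound 3 (beyond the scatter) and a number 11 percentage points higher from compound 2 to compound 3 (beyond the scatter).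

Compound 4 `COc1cc(N2C(N)=C(C#N)C(c3ccccc3)C3=C2CC(C)(C)CC3=O)cc(OC)c1OC` is the next member: phenyl in place of 5-methylfuran-2-yl on a saturated ring carbon. All three measured steps bear on this change, since each swaps the group on the same saturated ring carbon. Two of them, a number 21 percentage points higher from compound 1 to compound 3 (beyond the scatter) and a number 11 percentage points higher from compound 2 to compound 3 (beyond the scatter), were modest and beyond the scatter; the third, a number 10 percentage points higher from compound 1 to compound 2 (within the scatter), lay within it. Phenyl, a six-membered aromatic ring of carbon only, resembles 2-chlorophenyl more than 5-methylfuran-2-yl, so a modest decrease in this assay is expected, roughly undoing the gain seen in a number 11 percentage points higher from compound 2 to compound 3 (beyond the scatter). Compound 4 is therefore expected to give 11% in this assay, within a range of 0% to 25%. The expected step is a number 10 percentage points lower from compound 3 to compound 4 (within the scatter).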

Compound 4, a percentage reported as activity, at one concentration (the size of the read-out at that concentration, not a potency): 0%
Beside the measured number, compound 4's estimate is 11 percentage points above it, within the range that was stated.
By their numbers in this assay, from the lowest: compounds 1, 4 and 2 (each within the scatter of the next); then compound 3.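

With phenyl in place of 5-methylfuran-2-yl on the saturated ring carbon, this assay shows a number 21 percentage points lower from compound 3 to compound 4 (beyond the scatter) and so separates two aromatic rings of matching heavy-atom count. Removing the chloro gives a number 10 percentage points lower from compound 2 to compound 4 (within the scatter) and the change from 2-methoxynaphthalen-1-yl gives no change at the digits printed from compound 1 to compound 4 (within the scatter) so neither step separates the six-membered carbon-ring groups in compound 1, compound 2 and compound 4, while compound 3 stands apart from all three. No measurement shown accounts for the higher number with 5-methylfuran-2-yl.

As far as these compounds go, whether that number follows the ring oxygen or the methyl on the furan remains open, and furan-2-yl without the methyl or thiophen-2-yl would help to separate the two. Also open, from the compounds shown here alone, is whether a pyridine ring or an aminophenyl group at this carbon would give a higher number in this assay than compound 3, which gives 21%.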